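Moving the fluorine along the phenyl ring of compound 2

A few compounds are considered here, and "the series" means these few. Any claim that something is new, unique, unknown or untested is made for them only; others in the source may bear on it.

Measured compounds:
- compound 1, `CCc1cnc(N2CCC(n3nnc4cc(-c5ccc(S(C)(=O)=O)cc5)ncc43)CC2)nc1`: 21 nM
- compound 2, `CCc1cnc(N2CCC(n3nnc4cc(-c5ccc(S(C)(=O)=O)cc5F)ncc43)CC2)nc1`: 7 nM

Compound 1 was tested in a functional assay on HEK293 cells for agonist activity at Glucose-dependent insulinotropic receptor (Homo sapiens), read by HTRF and cAMP accumulation, with a stated time of 30 min (a lower number here means that less compound is needed, a higher number that more compound is needed for the effect), and gave 21 nM. Compound 2 carries one added fluorine and in this assay gives 7 nM, the lowest of the two numbers; the step of a 3.0-fold lower number from compound 1 to compound 2 (0.48 log units; beyond the scatter) lies beyond the scatter. Compound 3, `CCc1cnc(N2CCC(n3nnc4cc(-c5ccc(S(C)(=O)=O)c(F)c5)ncc43)CC2)nc1`, has not been measured. The change is 3-fluoro-4-(methylsulfonyl)phenyl in place of 2-fluoro-4-(methylsulfonyl)phenyl on an aromatic carbon, so the fluorine keeps its count but shifts its seat on the phenyl ring. Going by the values given here, only one measured step bears on this, a 3.0-fold lower number from compound 1 to compound 2 (0.48 log units; beyond the scatter), which concerns adding fluorine where compound 2 has it, not where compound 3 has it. Among the compounds with values here, there is no measured step for the 3-fluoro seat, so the gain of compound 2 need not carry over. Compound 3 is therefore expected to land between compound 1 and compound 2, with an estimated step of a 1.7-fold higher number from compound 2 to compound 3 (0.23 log units; within the scatter) and an estimated value of 12 nM, ranging from 4 nM to 40 nM.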

Compound 3, half-maximal effective concentration in the Glucose-dependent insulinotropic receptor assay: 9 nM
Compound 3: the middle estimate sits 1.3-fold (0.12 log units) above what was measured; the range from low to high includes it.
By their numbers in the Glucose-dependent insulinotropic receptor assay, from the lowest: compounds 2 and 3 (each within the scatter of the next); then compound 1.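

In the Glucose-dependent insulinotropic receptor assay, shifting the fluorine gives a 1.3-fold higher number from compound 2 to compound 3 (0.11 log units; within the scatter), and fluoro in place of hydrogen at the new seat still gives a 2.3-fold lower number from compound 1 to compound 3 (0.37 log units; beyond the scatter), so among these compounds the gain from fluorine appears with both 2-fluoro-4-(methylsulfonyl)phenyl and 3-fluoro-4-(methylsulfonyl)phenyl. In a physicochemical assay for solubility, read by HPLC, in phosphate buffer, measured as thermodynamic solubility, with a stated time of 24 h, at pH 6.8 (on this read-out higher numbers stand for higher solubility and lower numbers for lower solubility), compound 2 gives < 120 nM, a limit, not a number: the limit of < 120 nM in the physicochemical assay, at which 1 of the 2 values shown sits. In the physicochemical assay compound 3 gives < 150 nM, also only a limit, and the step between the two cannot be read: the limit of < 150 nM in the physicochemical assay, at which 1 of the 2 values shown sits.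

The compounds shown leave open whether chloro or nitrile at either seat would match fluoro in the Glucose-dependent insulinotropic receptor assay. They also leave open whether an amine or a carboxylic acid in place of the methylsulfonyl group would give a readable number in the physicochemical assay.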